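From compound 3 to compound 4: a changed amine substituent

The source may hold more compounds than are shown below. What is called first, only, known or untested is meant among the compounds shown, and "the series" means these compounds.

Measured so far in a functional assay on MCF7 cells (Homo sapiens) for inhibition, read by MTT assay, with a stated time of 3 days (a lower number here means a stronger inhibitor, a higher number a weaker inhibitor), are these compounds:

- compound 1 `CC[C@H](C)[C@H](NCC(=O)NNC(=O)COc1ccc(-c2nc3ccccc3s2)cc1OC)C(=O)O` gives 1710 nM
- compound 2 `COc1cc(-c2nc3ccccc3s2)ccc1OCC(=O)NNC(=O)CN[C@@H](CS(=O)(=O)O)C(=O)O` gives 1870 nM
- compound 3 `COc1cc(-c2nc3ccccc3s2)ccc1OCC(=O)NNC(=O)CN[C@@H](CCSC)C(=O)O` gives 1950 nM

The three values sit together, and compound 3 (1950 nM) lies within the scatter of both others. Compound 4 `CCOC(=O)[C@H](CS)NCC(=O)NNC(=O)COc1ccc(-c2nc3ccccc3s2)cc1OC` carries 1-(ethoxycarbonyl)-2-sulfanylethyl in place of 1-carboxy-3-(methylsulfanyl)propyl on an amine nitrogen. Among the compounds with values here, three measured steps bear on this change, and each lies within the scatter (a 1.1-fold higher number from compound 1 to compound 2 (0.04 log units; within the scatter)), (a 1.1-fold higher number from compound 1 to compound 3 (0.06 log units; within the scatter)) and (a 1.0-fold higher number from compound 2 to compound 3 (0.02 log units; within the scatter)). All three alter only the side chain, and all three compounds keep the carboxy group. Within the data shown here, the replacement of carboxy by ethoxycarbonyl therefore has no measured counterpart here, which leaves the estimate less certain. From the side-chain steps alone, the expected change (a 1.1-fold lower number from compound 3 to compound 4 (0.06 log units; within the scatter)) stays within the scatter in this assay and has no firm direction. Compound 4 is expected to give about 1700 nM with an estimated range from 650 nM to 3800 nM as its likely span.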

Compound 4, half-maximal inhibitory concentration: 2880 nM
For compound 4 the middle estimate is 1.7-fold (0.23 log units) below the measured one; measured number inside the range.
By their numbers in this assay, from the lowest: compounds 1, 2, 3 and 4 (each within the scatter of the next).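

In this assay, within the data shown here, ethoxycarbonyl appears here for the first time in place of the carboxy group, and compound 4 stays within the scatter of all three earlier compounds (a 1.5-fold higher number from compound 3 to compound 4 (0.17 log units; within the scatter)), (a 1.5-fold higher number from compound 2 to compound 4 (0.19 log units; within the scatter)) and (a 1.7-fold higher number from compound 1 to compound 4 (0.23 log units; within the scatter)). At this amine nitrogen, then, a free carboxy group is not needed for a value of this order among these four compounds, although the ester and the sulfanyl side chain enter together and their shares cannot be separated. Nothing available explains this result.

An ethyl ester carrying the 2-(methylsulfanyl)ethyl side chain, or a free carboxylic acid carrying the sulfanylmethyl side chain, would tell the two parts apart. Going by these compounds, it also remains open whether a primary amide or a benzyl ester at this carbonyl would stay in the same range.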